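Methylation of one catechol in a glycosylated diarylheptanoid

A few compounds are considered here, and "the series" means these few. Any claim that something is new, unique, unknown or untested is made for them only; others in the source may bear on it.

Two glycosylated diarylheptanoids were examined in a functional assay on HSC-2 cells (Homo sapiens) for cytotoxicity, read by MTT assay; on this read-out higher numbers stand for weaker inhibition and lower numbers for stronger inhibition. Compound 1 `COc1cc(CC[C@H](C[C@H](O)CCc2ccc(O)cc2)O[C@@H]2O[C@H](CO)[C@@H](O)[C@H](O)[C@H]2O)ccc1O` gives 160 ug/mL in this assay. Compound 2 `OC[C@H]1O[C@@H](O[C@H](CCc2ccc(O)c(O)c2)C[C@H](O)CCc2ccc(O)c(O)c2)[C@H](O)[C@@H](O)[C@@H]1O` gives 92 ug/mL, the lowest of the two numbers recorded, though its gap to compound 1 lies within the scatter of repeated measurements, so the two cannot be ranked against each other.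

Compound 3 `COc1cc(CC[C@H](C[C@H](O)CCc2ccc(O)c(O)c2)O[C@@H]2O[C@H](CO)[C@@H](O)[C@H](O)[C@H]2O)ccc1O` has not yet been measured in this assay. It differs from compound 2 in one place: methyl in place of hydrogen on an oxygen on an aromatic ring. The change reads hydroxy to methoxy on one ring, turning a 3,4-dihydroxyphenyl into a 4-hydroxy-3-methoxyphenyl, while the other ring keeps its 3,4-dihydroxyphenyl.

Within the data shown here, since no single-point step between measured compounds exists here, the expectation rests on the two values alone. The step of a 1.3-fold higher number from compound 2 to compound 3 (0.12 log units; within the scatter) is expected to stay within the scatter, pointing, if anywhere, toward the number of compound 1. Compound 3 is therefore estimated at 120 ug/mL, with a likely range from 70 ug/mL to 210 ug/mL.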

Compound 3, half-maximal inhibitory concentration: 209 ug/mL
Compound 3: middle estimate off by 1.7-fold (0.24 log units), on the low side; the measured number falls inside the stated range.
By their numbers in this assay, from the lowest: compounds 2, 1 and 3 (each within the scatter of the next, the first and the last beyond it).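

In this assay, among these compounds, methyl in place of hydrogen on an oxygen on an aromatic ring, hydroxy to methoxy, gives a 2.3-fold higher number from compound 2 to compound 3 (0.36 log units; beyond the scatter) and so provides the one single-place step here that lies beyond the scatter, though only modestly. The free hydroxy at this place therefore has a small but readable bearing on this read-out. The other change, hydroxy in place of hydrogen on an aromatic carbon, gives a 1.3-fold higher number from compound 1 to compound 3 (0.12 log units; within the scatter) and stays within the scatter, so this pair shows no readable effect of that hydroxy. Nothing measured here gives a reason for either step. From the compounds shown here alone, it remains open whether a longer chain such as ethyl on this oxygen, or an amine in place of the hydroxy, would follow the same direction. Also open, going by these compounds, is whether methyl on an oxygen of the other 3,4-dihydroxyphenyl would give a step of similar size.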